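The source may report more compounds than this note shows. Statements on the series, on what has been measured and on what is new or still open speak of the compounds shown alone.

In a functional assay on HOS-TE85 cells (Homo sapiens) for inhibition, read by CCK-8 assay, with a stated time of 72 h (on this read-out higher numbers stand for weaker inhibition and lower numbers for stronger inhibition), compound 1 (`COc1ccc(C)cc1N1C(=O)CSC1c1cccc(C(=O)NCCCCc2ccccc2)c1`) gives 300 nM and compound 2 (`COc1ccc(F)cc1N1C(=O)CSC1c1cccc(C(=O)NCCCCn2cccn2)c1`) gives 97.3 nM which is the lower of the two numbers, with a gap beyond the scatter. Compound 3 (`O=C(NCCCCn1cccn1)c1cccc(C2SCC(=O)N2c2cc(Br)ccn2)c1`) has 4-bromopyridin-2-yl in place of 5-fluoro-2-methoxyphenyl on an amide-type nitrogen in a ring. Among the compounds with values here, no measured pair shows this change, so the direction is uncertain, but a moderate move to a higher number is expected in this assay for this change. The expected step (a 2.6-fold higher number from compound 2 to compound 3 (0.41 log units; beyond the scatter)) is only an estimate. Compound 3 is estimated at 250 nM with an expected range of 70 nM to 900 nM on this evidence.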

Compound 3, half-maximal inhibitory concentration: 105 nM
Estimate against measurement, compound 3: 2.4-fold (0.38 log units) above; low and high end bracket the measured number.
By their numbers in this assay, from the lowest: compounds 2 and 3 (each within the scatter of the next); then compound 1.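

In this assay, 4-bromopyridin-2-yl in place of 5-fluoro-2-methoxyphenyl on the amide-type nitrogen in the ring gives a 1.1-fold higher number from compound 2 to compound 3 (0.03 log units; within the scatter). This position therefore accepts a six-membered aromatic ring with a hetero atom, without methoxy or fluorine, and with no difference beyond the scatter on this read-out. No measurement at hand explains this result.

The step exchanges the ring and its substituents at once, leaving the separate contributions of the pyridine nitrogen and the bromine open. Also open, as far as these compounds go, is how an unsubstituted pyridin-2-yl would read at this position.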